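Methylsulfanyl in Place of Ethoxy: Expected Cytotoxicity

A few compounds are considered here, and "the series" means these few. Any claim that something is new, unique, unknown or untested is made for them only; others in the source may bear on it.

Compound 1 `CCOc1nc(N)nc2c1ncn2/C=C1/CC1(CO)CO` gives > 300000 nM in an ADME assay on HFF cells (Homo sapiens) for cytotoxicity, with a stated time of 8 days (a lower number here means that less compound is tolerated, a higher number that more compound is tolerated), a limit of the assay.
Compound 2 `COCCOc1nc(N)nc2c1ncn2/C=C1/CC1(CO)CO` gives > 300000 nM in this assay, a limit of the assay.
Compound 3 `Nc1nc(N2CCCC2)c2ncn(/C=C3/CC3(CO)CO)c2n1` gives > 300000 nM in this assay, a limit of the assay.

Compound 1 stands where every measured compound of this set stands: the limit of > 300000 nM in this assay, at which 3 of the 3 values shown sit. Only a limit is known for it, so its true tolerated concentration is not placed on a number.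

The compound still to be measured, compound 4 `CSc1nc(N)nc2c1ncn2/C=C1/CC1(CO)CO`, differs from compound 1 in one place: methylsulfanyl in place of ethoxy on an aromatic carbon.

Two measured steps start from compound 1 and alter the same position. One is a step that the two limits leave unreadable from compound 1 to compound 2; the other is a step that the two limits leave unreadable from compound 1 to compound 3. The third, a step that the two limits leave unreadable from compound 2 to compound 3, joins the two altered compounds. None of them can be read, because each end sits at the limit (the limit of > 300000 nM in this assay, at which 3 of the 3 values shown sit). Nothing measured therefore points to a change in this assay in either direction; the expectation is a step no larger than the scatter, and most likely another limit.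

For compound 4 the estimate in this assay is 400000 nM, with a range from 150000 nM to 1500000 nM. This estimate means a step that the limit leaves unreadable from compound 1 to compound 4, expected to remain unreadable.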

Compound 4, half-maximal cytotoxic concentration: > 300000 nM
Compound 4: no number, only a limit; the forecaster's own chance of this, stated with the estimate: 80%; the middle value is on the limit's open side.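

In this assay compound 4 gives > 300000 nM as a limit of the assay. Its steps from compound 1, compound 2 and compound 3 cannot be read, because all four compounds sit at one limit: the limit of > 300000 nM in this assay, at which 4 of the 4 values shown sit. The compounds shown leave open at what concentration any of them becomes cytotoxic, and whether methylsulfanyl, ethoxy, 2-methoxyethoxy or pyrrolidin-1-yl on this aromatic carbon changes that concentration.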